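Methyl on an aromatic carbon of compound 1

A few compounds are considered here, and "the series" means these few. Any claim that something is new, unique, unknown or untested is made for them only; others in the source may bear on it.

Among the compounds with values here, compound 1 `N#Cc1ccc(C(O)(c2cocn2)C(F)(F)F)cc1C(F)(F)F` gives 8 h in an ADME assay on the whole organism (strain Wistar Han) for metabolic stability, with Rattus norvegicus as the target, read by LC-MS, at a dose of 5 mg/kg by the oral route (on this read-out higher numbers stand for a longer-lived compound and lower numbers for a shorter-lived compound), and stands lowest of the two numbers so far. Within the data shown here, compound 2 `CCC(O)(c1ccc(C#N)c(C(F)(F)F)c1)C(F)(F)F` gives 83 h in this assay and is the only comparison available. Among the measured compounds shown here, the single measured step is a 10-fold higher number from compound 1 to compound 2 (1.02 log units; beyond the scatter) with ethyl in place of 1,3-oxazol-4-yl on a saturated chain carbon. Compound 3 `Cc1c(C(O)(c2cocn2)C(F)(F)F)ccc(C#N)c1C(F)(F)F` differs from compound 1 by methyl in place of hydrogen on an aromatic carbon with methyl in place of hydrogen on an aromatic carbon, ortho to a trifluoromethyl group and meta to a cyano group. The measured step lies at another place and sets no size for this change. The expectation therefore starts from compound 1 at 8 h and allows only a slight rise. The expected step is a 1.3-fold higher number from compound 1 to compound 3 (0.10 log units; within the scatter) and should stay within the scatter. The estimate for compound 3 is 10 h with an expected range of 4 h to 25 h as half-life.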

Compound 3, half-life in the Rattus norvegicus assay: 5.5 h
Compound 3: middle estimate off by 1.8-fold (0.26 log units), on the high side; measured number inside the range.
By their numbers in the Rattus norvegicus assay, from the lowest: compounds 3 and 1 (each within the scatter of the next); then compound 2.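

Within the data shown here, in the Rattus norvegicus assay, methyl in place of hydrogen on this aromatic carbon, ortho to a trifluoromethyl group and meta to a cyano group, gives a 1.5-fold lower number from compound 1 to compound 3 (0.16 log units; within the scatter), so the half-life at this position shows no change beyond the scatter, whereas the only earlier step, a 10-fold higher number from compound 1 to compound 2 (1.02 log units; beyond the scatter), lay at the saturated chain carbon. In a physicochemical assay for solubility, read by chemiluminescence, in phosphate buffer, measured as kinetic solubility, with a stated time of 1 h, at pH 7.4 (on this read-out lower numbers stand for lower solubility and higher numbers for higher solubility), compound 1 gives > 700000 nM, which is a limit of the assay. In the physicochemical assay compound 3 gives > 400000 nM, also a limit, so the step between the two cannot be read.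

The compounds shown leave open whether a longer chain, a methoxy group or an amine on this aromatic carbon would also stay within the scatter of compound 1. They also leave open what the same methyl does when ethyl stands in place of 1,3-oxazol-4-yl, as in compound 2.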